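Changing the amide group of compound 3

The source may report more compounds than this note shows. Statements on the series, on what has been measured and on what is new or still open speak of the compounds shown alone.

Values in a functional assay on HepG2 cells (Homo sapiens) for antiproliferative activity, read by MTT assay, with a stated time of 48 h; on this read-out lower numbers stand for stronger inhibition and higher numbers for weaker inhibition:
- compound 1 `CCn1c(C(=O)NCCCN(C)C)ccc1C(CC)(CC)c1ccc(OCCC(O)(CC)CC)c(C)c1`: 110 nM
- compound 2 `CCOC(=O)C(CC(=O)OC)NC(=O)c1ccc(C(CC)(CC)c2ccc(OCCC(O)(CC)CC)c(C)c2)n1CC`: > 50000 nM, a limit of the assay and not a number
- compound 3 `CCn1c(C(=O)N(C)CC(=O)O)ccc1C(CC)(CC)c1ccc(OCCC(O)(CC)CC)c(C)c1`: 5710 nM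

Compound 3, at 5710 nM, has the higher of the two true numbers, and compound 1 is its nearest neighbour. Compound 2 gives only a limit.

The next molecule is compound 4 `CCC(C)C(CO)NC(=O)c1ccc(C(CC)(CC)c2ccc(OCCC(O)(CC)CC)c(C)c2)n1CC`, with (1-(hydroxymethyl)-2-methylbutyl)amino in place of (carboxymethyl)(methyl)amino on a carbonyl carbon.

All three measured steps are changes on this same carbonyl carbon, and all lie beyond the scatter. There is a 52-fold higher number from compound 1 to compound 3 (1.72 log units; beyond the scatter), which is large. There is also an at least 8.7-fold lower number from compound 2 to compound 3 (0.94 log units; beyond the scatter), which is at least modest, and an at least 450-fold higher number from compound 1 to compound 2 (2.65 log units; beyond the scatter), which is large. Steps here can therefore be big, but they run both ways from compound 3, so the direction stays uncertain. A modest move toward a lower number is expected, and the range is kept wide.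

The expected change is a 2.9-fold lower number from compound 3 to compound 4 (0.46 log units; beyond the scatter).

For compound 4 the estimated value in this assay is 2000 nM, with an expected range of 300 nM to 15000 nM.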

Compound 4, half-maximal inhibitory concentration: > 50000 nM
Compound 4: only a limit was reported; the forecaster's own chance of this, stated with the estimate: 12%; middle value at least 25-fold (1.39 log units) from the limit.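

Replacing (carboxymethyl)(methyl)amino with (1-(hydroxymethyl)-2-methylbutyl)amino on the carbonyl carbon gives an at least 8.7-fold higher number from compound 3 to compound 4 (0.94 log units; beyond the scatter), so a group without a carboxylic acid can still score worse here. Measured against the 3-(dimethylamino)propyl group on the amide-type nitrogen, the new group gives an at least 450-fold higher number from compound 1 to compound 4 (2.65 log units; beyond the scatter), and all three other amide groups shown now fall well short of that one. The value of compound 4 is a limit of the assay and not a number, and compound 2 also gives only a limit, so the step between them cannot be read: the limit of > 50000 nM in this assay, at which 2 of the 4 values shown sit.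

The compounds shown leave open whether the activity of compound 1 depends on the terminal dimethylamino group or on the length of its chain. A 2-(dimethylamino)ethyl chain, a 4-(dimethylamino)butyl chain or a plain propyl chain on the amide nitrogen would help separate the two.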